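Extending the triazole side chain toward a fluorophenyl amide

This account rests on a few compounds, and the source may have more. Where it says the series, first, only, none or still open, it means among the compounds named here.

The series shares a core carrying a triazole linked through a saturated chain carbon to an aromatic carbon. Compound 1 `O=C(NCc1cn(Cc2ccc3oc(-c4ccccc4)cc(=O)c3c2)nn1)c1ccccc1` gives 15600 nM in an assay on isolated protein for inhibition of Amine oxidase [flavin-containing] B (Homo sapiens), read by fluorescence and spectrophotometry (a lower number here means a stronger inhibitor, a higher number a weaker inhibitor), the lowest number of the two measured compounds. Compound 2 `O=C(NCc1cnnn1Cc1ccc2oc(-c3ccc(Cl)cc3)cc(=O)c2c1)c1ccccc1` gives 32900 nM in this assay, a number that lies beyond the scatter above that of compound 1.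

Compound 3 `O=C(CCc1cn(Cc2ccc3oc(-c4ccccc4)cc(=O)c3c2)nn1)Nc1ccc(F)cc1` has not yet been measured. It differs from compound 1 by ((4-fluorophenyl)carbamoyl)methyl in place of benzamido on a saturated chain carbon bound to an aromatic carbon. Going by the values given here, no measured pair shows this kind of change, so nothing in the data fixes its size or direction. The expectation for the step from compound 1 to compound 3 in this assay is therefore a small one, a 1.3-fold lower number from compound 1 to compound 3 (0.11 log units; within the scatter), leaning slightly toward a stronger inhibitor but within the usual scatter.

Compound 3 is expected to give about 12000 nM in this assay, with a range from 4000 nM to 40000 nM.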

Compound 3, half-maximal inhibitory concentration: 15600 nM
Compound 3: middle estimate off by 1.3-fold (0.11 log units), on the low side; measured number inside the range.
By their numbers in this assay, from the lowest: compounds 1 and 3 (each within the scatter of the next); then compound 2.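

In this assay, ((4-fluorophenyl)carbamoyl)methyl in place of benzamido on a saturated chain carbon bound to an aromatic carbon gives no change at the digits printed from compound 1 to compound 3 (within the scatter). Going by these compounds alone, this is the first step read at this position, and it shows that the position takes a group with more heavy atoms and a fluorine without moving the number. The data shown offer no measurement that would account for this result.

The step alters the chain and adds the fluorine together, and the two contributions are not told apart. As far as these compounds go, whether an unsubstituted phenyl amide on the same chain, or an amine or a carboxylic acid in place of the amide, would also leave the number unmoved in this assay remains open.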